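This account rests on a few compounds, and the source may have more. Where it says the series, first, only, none or still open, it means among the compounds named here.

Compound 3 `O=S(=O)(Nc1nccs1)c1ccc2c(c1)OCC[C@@H]2c1ccc(C(F)(F)F)cc1-n1ccnn1` gives 79% in an ADME assay on the whole organism (Mus musculus, strain BALB/c) for pharmacokinetics, read by LC-MS, with a stated time of 24 h, at a dose of 10 mg/kg by the oral route (a higher number here means that a larger share of the oral dose reaches the circulation, a lower number that a smaller share of the oral dose reaches the circulation), the higher of the two actual numbers in the series. Compound 2 `Cn1nccc1-c1cc(C(F)(F)F)ccc1[C@H]1CCOc2cc(S(=O)(=O)Nc3nccs3)ccc21` gives 68%. For the measured compounds named here, the step between them is a number 11 percentage points higher from compound 2 to compound 3 (beyond the scatter), and it is the only measured step that isolates a change at this aromatic carbon.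

Compound 4 `O=S(=O)(Nc1nccs1)c1ccc2c(c1)OCC[C@@H]2c1ccc(C(F)(F)F)cc1-c1ccc(F)nc1` carries 6-fluoropyridin-3-yl in place of 1H-1,2,3-triazol-1-yl on an aromatic carbon. Going by the values given here, no measured step covers this exchange directly.

Compound 1 `O=S(=O)(Nc1ncccn1)c1ccc2c(c1)OCC[C@@H]2c1ccc(C(F)(F)F)cc1-c1ccc(F)nc1`, which bears the same 6-fluoropyridin-3-yl group, reads > 100% in this assay, a limit of the assay and not a number. Compound 1 is not otherwise identical to compound 4, so it suggests a direction but gives no size.

The only measured size is the modest one from the triazole exchange, so a small upward change is expected, possibly not clear of the scatter. The expected change in this assay is a number 9 percentage points higher from compound 3 to compound 4 (within the scatter). The estimate for compound 4 is 88%, with an expected range of 62% to 112%.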

Compound 4, oral bioavailability: 95%
The estimate for compound 4 lay 7 percentage points below the measured number, and the stated range covers the measured number.
By their numbers in this assay, from the lowest: compound 2; then compound 3; then compound 4. At a limit, above all of these: compound 1.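

At this aromatic carbon, meta to a trifluoromethyl group, the series in this assay now extends upward with 6-fluoropyridin-3-yl: a number 16 percentage points higher from compound 3 to compound 4 (beyond the scatter), and a number 27 percentage points higher from compound 2 to compound 4 (beyond the scatter). The three groups on the thiazolyl sulfonamide therefore fall in a clear order, with the six-membered aromatic ring above both five-membered ones, although this rests on a single six-membered example. With 6-fluoropyridin-3-yl held constant, 1,3-thiazol-2-yl in place of pyrimidin-2-yl on the sulfonamide nitrogen gives a number at least 5 percentage points lower from compound 1 to compound 4 (that floor lies within the scatter), a step that starts from a limit and not a number, so it gives no size: the limit of > 100% in this assay, at which 1 of the 4 values shown sits.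

The compounds shown do not explain the order among the three groups. Also open, from the compounds shown here alone, is how a phenyl ring, an amine or a carboxylic acid at this carbon would read in this assay.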